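Uridine triphosphate oxime ethers: aryl change at the chain end

The source may hold more compounds than are shown below. What is called first, only, known or untested is meant among the compounds shown, and "the series" means these compounds.

Measured so far in a functional assay on 1321-N1 cells for agonist activity at P2Y purinoceptor 2 (Homo sapiens), read by scintillation counting and inositol phosphate accumulation; on this read-out lower numbers stand for an effect already at smaller amounts and higher numbers for an effect only at larger amounts of compound:
- compound 1, `O=c1[nH]/c(=N\OCCCc2ccc(F)cc2)ccn1[C@@H]1O[C@H](COP(=O)(O)OP(=O)(O)OP(=O)(O)O)[C@@H](O)[C@H]1O`, gives 547 nM
- compound 2, `O=c1[nH]/c(=N\OCCCc2ccc(I)cc2)ccn1[C@@H]1O[C@H](COP(=O)(O)OP(=O)(O)OP(=O)(O)O)[C@@H](O)[C@H]1O`, gives 187 nM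
- compound 3, `C#CCCCO/N=c1/ccn([C@@H]2O[C@H](COP(=O)(O)OP(=O)(O)OP(=O)(O)O)[C@@H](O)[C@H]2O)c(=O)[nH]1`, gives 168 nM

Compound 1 gives the highest number of the three; its nearest neighbour is compound 2, with a 2.9-fold lower number from compound 1 to compound 2 (0.47 log units; beyond the scatter), and its furthest is compound 3, with a 3.3-fold lower number from compound 1 to compound 3 (0.51 log units; beyond the scatter). The two lower-numbered compounds sit together, as seen in a 1.1-fold lower number from compound 2 to compound 3 (0.05 log units; within the scatter).

Compound 4, `O=c1[nH]/c(=N\OCCCc2ccc3ccccc3c2)ccn1[C@@H]1O[C@H](COP(=O)(O)OP(=O)(O)OP(=O)(O)O)[C@@H](O)[C@H]1O`, is the next step from compound 1: naphthalen-2-yl in place of 4-fluorophenyl on a saturated chain carbon, three bonds along the chain from an oxygen.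

Both measured steps out of compound 1 change the same chain end and both give lower numbers of modest size in this assay, whether a larger halogen is put on the ring, as in a 2.9-fold lower number from compound 1 to compound 2 (0.47 log units; beyond the scatter), or the ring is replaced altogether, as in a 3.3-fold lower number from compound 1 to compound 3 (0.51 log units; beyond the scatter). Nothing measured here carries a second aromatic ring, so the extension to naphthalen-2-yl is extrapolated. On these steps a modest drop in number, in the direction of compound 2, is expected, roughly a 2.2-fold lower number from compound 1 to compound 4 (0.34 log units; beyond the scatter). The estimate for compound 4 in this assay is 250 nM, with a range of 80 nM to 800 nM.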

Compound 4, half-maximal effective concentration: 139 nM
Estimate against measurement, compound 4: 1.8-fold (0.25 log units) above; the range from low to high includes it.
By their numbers in this assay, from the lowest: compounds 4, 3 and 2 (each within the scatter of the next); then compound 1.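

Notes on the chain end: in this assay, naphthalen-2-yl in place of 4-fluorophenyl, on a saturated chain carbon, three bonds along the chain from an oxygen, gives a 3.9-fold lower number from compound 1 to compound 4 (0.59 log units; beyond the scatter), so a second aromatic ring is tolerated at this place. The step of a 1.3-fold lower number from compound 2 to compound 4 (0.13 log units; within the scatter) and the step of a 1.2-fold lower number from compound 3 to compound 4 (0.08 log units; within the scatter) both stay within the scatter, leaving 4-fluorophenyl alone apart from the other three chain ends, while 4-iodophenyl, ethynyl and naphthalen-2-yl cannot be told apart here. No measurement at hand explains why these different chain ends give such similar numbers.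

Open, as far as these compounds go, is whether naphthalen-1-yl or 4-chlorophenyl would sit with this group in this assay or with compound 1. Also open, from the compounds shown here alone, is how an amine or a carboxylic acid at the chain end, or a longer chain carrying naphthalen-2-yl, would read.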